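Benzyl substituent exchange in the cinnamamide series

The source may hold more compounds than are shown below. What is called first, only, known or untested is meant among the compounds shown, and "the series" means these compounds.

Compound 2 `CC(C)(C)c1cc(/C=C/C(=O)NCCC2CCN(Cc3ccc(F)c(F)c3)CC2)cc(C(C)(C)C)c1O` gives 9300 nM in an assay on isolated protein for inhibition of Amine oxidase [flavin-containing] B (Homo sapiens), read by fluorescence, with stated times of 15 min and 20 min; a lower number here means a stronger inhibitor, a higher number a weaker inhibitor. Compound 1 `CC(C)(C)c1cc(/C=C/C(=O)NCCC2CCN(Cc3cccc(F)c3)CC2)cc(C(C)(C)C)c1O` gives 6500 nM in this assay, and the step of a 1.4-fold higher number from compound 1 to compound 2 (0.16 log units; within the scatter) lies within the scatter, so the two values cannot be told apart. Compound 3 `CC(C)(C)c1cc(/C=C/C(=O)NCCC2CCN(Cc3cccc([N+](=O)[O-])c3)CC2)cc(C(C)(C)C)c1O` carries 3-nitrophenyl in place of 3,4-difluorophenyl on a saturated chain carbon bound to an amine nitrogen in a ring. Among the measured compounds shown here, no measured step exchanges fluorine for a nitro group; the only step touching the benzyl ring, a 1.4-fold higher number from compound 1 to compound 2 (0.16 log units; within the scatter), was within the scatter. For compound 3 the expectation is therefore no step beyond the scatter, a 1.2-fold lower number from compound 2 to compound 3 (0.09 log units; within the scatter). Compound 3 is estimated at 7500 nM in this assay, with a range from 2500 nM to 22000 nM.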

Compound 3, half-maximal inhibitory concentration: 12500 nM
Compound 3: middle estimate off by 1.7-fold (0.22 log units), on the low side, within the range that was stated.
By their numbers in this assay, from the lowest: compounds 1, 2 and 3 (each within the scatter of the next).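

In this assay the step to 3-nitrophenyl on a saturated chain carbon bound to an amine nitrogen in a ring, a 1.3-fold higher number from compound 2 to compound 3 (0.13 log units; within the scatter), and nitro in place of fluoro, a 1.9-fold higher number from compound 1 to compound 3 (0.28 log units; within the scatter), both stay within the scatter. The earlier pair covered only fluoro in place of hydrogen; this place now also takes a nitro group, with its two hydrogen-bond acceptors, without a readable shift. No supporting data bear on this result.

On these data alone, whether an amine or a carboxylic acid on the benzyl ring would move the number beyond the scatter remains open. So does the effect of an unsubstituted benzyl group.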